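Cytotoxicity of Dinonyl Aminosugars: From Compound 3 to Compound 4

A few compounds are considered here, and "the series" means these few. Any claim that something is new, unique, unknown or untested is made for them only; others in the source may bear on it.

Measured so far:
Compound 1, `CCCCCCCCCO[C@@H]1[C@@H](N)[C@@H](OCC(O)CNCCO)O[C@H](CN)[C@H]1OCCCCCCCCC`, 99.1%
Compound 2, `CCCCCCCCCO[C@@H]1[C@@H](N)[C@@H](OCC(O)CNCCCO)O[C@H](CN)[C@H]1OCCCCCCCCC`, 89.9%
Compound 3, `C=CCO[C@H]1O[C@H](CN)[C@@H](OCCCCCCCCC)[C@H](OCCCCCCCCC)[C@H]1N`, 91.4%

All three values come from a toxicity assay on the whole organism (J774 cells) for cytotoxicity, with Mus musculus as the target, read by MTT assay, with a stated time of 24 h, tested at 10 uM; on this read-out lower numbers stand for a stronger effect and higher numbers for a weaker effect at the one concentration tested. Compound 3 stands second highest of the three numbers, but its gaps to the others, a number 7.7 percentage points lower from compound 1 to compound 3 (within the scatter) and a number 1.5 percentage points higher from compound 2 to compound 3 (within the scatter), both lie within the scatter, so no order among them can be claimed.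

Compound 4, `CCCCCCCCCO[C@@H]1[C@@H](N)[C@@H](O[C@H]2[C@H](O)[C@@H](O)[C@H](N)C[C@@H]2N)O[C@H](CN)[C@H]1OCCCCCCCCC`, has not been measured. The change is 4,6-diamino-2,3-dihydroxycyclohexyl in place of allyl on an oxygen on a saturated carbon. The two steps that bear on it, a number 7.7 percentage points lower from compound 1 to compound 3 (within the scatter) and a number 1.5 percentage points higher from compound 2 to compound 3 (within the scatter), altered the same position and stayed within the scatter, so no step beyond the scatter is expected here either: the expected step is a number 1.6 percentage points higher from compound 3 to compound 4 (within the scatter). Compound 4 is estimated at 93%, within 78% to 100%.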

Compound 4, a percentage reported as activity, at one concentration (the size of the read-out at that concentration, not a potency): 82.7%
Compound 4: middle estimate off by 10.3 percentage points, on the high side; low and high end bracket the measured number.
By their numbers in this assay, from the lowest: compounds 4, 2, 3 and 1 (each within the scatter of the next, the first and the last beyond it).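

Among the compounds shown here, with 4,6-diamino-2,3-dihydroxycyclohexyl on this oxygen, this assay gives the first step here that clears the scatter, a number 16.4 percentage points lower from compound 1 to compound 4 (beyond the scatter), so changing this group can shift the read-out. The same group does not separate from allyl or from 2-hydroxy-3-((3-hydroxypropyl)amino)propyl, with a number 8.7 percentage points lower from compound 3 to compound 4 (within the scatter) and a number 7.2 percentage points lower from compound 2 to compound 4 (within the scatter) as the steps. Nothing available explains why only the first comparison clears the scatter. From the compounds shown here alone, how a carboxylic acid or a longer chain on this oxygen would read remains open.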